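The compounds below may be only part of what the source reports. "The series", "measured", "known", "first", "only" and "open" are said of these compounds alone.

Measured so far in a functional assay on CWR22R cells (Homo sapiens) for antiproliferative activity, read by propidium iodide staining, with a stated time of 96 h; on this read-out higher numbers stand for weaker inhibition and lower numbers for stronger inhibition:
Compound 1 `CC(O)(CSc1ccc(S(F)(F)(F)(F)F)cc1)C(=O)Nc1ccc(S(F)(F)(F)(F)F)cc1` gives 24400 nM.
Compound 2 `CC(O)(CSc1ccc(OC(F)(F)F)cc1)C(=O)Nc1ccc(S(F)(F)(F)(F)F)cc1` gives 14900 nM.
Compound 3 `CC(O)(COc1ccc(S(F)(F)(F)(F)F)cc1)C(=O)Nc1ccc(S(F)(F)(F)(F)F)cc1` gives 13000 nM.

The account concerns one structural change. From compound 1 to compound 2 the change is a group of 5 heavy atoms (1 carbon, 1 oxygen, 3 fluorine; no ring) in place of a group of 6 heavy atoms (5 fluorine, 1 sulfur; no ring), on an aromatic carbon, and in this assay it produced a 1.6-fold lower number from compound 1 to compound 2 (0.21 log units; within the scatter). Compound 4 `CC(O)(COc1ccc(OC(F)(F)F)cc1)C(=O)Nc1ccc(S(F)(F)(F)(F)F)cc1` stands to compound 3 as compound 2 stands to compound 1: the change is a group of 5 heavy atoms (1 carbon, 1 oxygen, 3 fluorine; no ring) in place of a group of 6 heavy atoms (5 fluorine, 1 sulfur; no ring), on an aromatic carbon, and since the surroundings of the place read the same in both cases, it is the same change. How the core of compound 1 differs from the core of compound 3 is not broken down here; the values of compound 1 and compound 3 lie within the scatter of each other, as do those of compound 2 and compound 3.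

Among the compounds with values here, the expected step from compound 3 to compound 4 in this assay is a 1.5-fold lower number from compound 3 to compound 4 (0.18 log units; within the scatter), set beside the earlier step because the same change gave a 1.6-fold lower number from compound 1 to compound 2 (0.21 log units; within the scatter); with only one prior instance, the expectation carries wide bounds. Compound 4 is therefore estimated at 8500 nM, expected to fall between 4000 nM and 17000 nM.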

Compound 4, half-maximal inhibitory concentration: 27900 nM
The estimate for compound 4 lay 3.3-fold (0.52 log units) below the measured number; the measured number lies above the stated range.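

In this assay, putting trifluoromethoxy in place of the sulfur group with its fluorines, on the core of compound 3, gave a 2.1-fold higher number from compound 3 to compound 4 (0.33 log units; beyond the scatter), a modest step. Set beside the earlier case on the core of compound 1, the change did not carry over as a fixed increment, since the two steps differ: the same change on two cores in this assay, a 1.6-fold lower number (0.21 log units; within the scatter) from compound 1 to compound 2 and a 2.1-fold higher number (0.33 log units; beyond the scatter) from compound 3 to compound 4, 3.5-fold (0.55 log units) apart, beyond the scatter of two such steps This shows that, in this small set, the effect of the change depends on the core that carries it, but it does not show a clean reversal, as the earlier step lies within the scatter, and two cases cannot say which feature of the cores is responsible.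

The compounds shown leave open how the same change would read on further cores, and how a nitrile or a chlorine would compare at the same place on the ring. They also leave open whether these steps would hold if the group on the amide side, identical in all four compounds, were replaced by another, such as a nitrile.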